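From compound 2 to compound 3: an aryl exchange

The source may report more compounds than this note shows. Statements on the series, on what has been measured and on what is new or still open speak of the compounds shown alone.

Measured compounds:
compound 1, `CC1CC1c1cc(NC(=O)Cn2nnc(-c3ccccc3)n2)n(C2CCCCC2)n1`, 843 nM
compound 2, `Cc1cc(NC(=O)Cn2nnc(-c3ccnc(F)c3)n2)n(C2CCCCC2)n1`, 441 nM

In an assay on HEK293 cells for activation of Kir3.1/Kir3.2 (Homo sapiens), read by thallium flux (on this read-out higher numbers stand for an effect only at larger amounts of compound and lower numbers for an effect already at smaller amounts), compound 2 gives 441 nM, while compound 1 gives 843 nM in this assay; the gap between the two lies within the usual scatter of repeated measurements, so the two cannot be told apart on these numbers. Going by the values given here, no pair of measured compounds differs in only one place, so no single step has been measured here.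

Compound 3, `Cc1cc(NC(=O)Cn2nnc(-c3ccc(Cl)c(C)c3)n2)n(C2CCCCC2)n1`, has not yet been measured. It differs from compound 2 in one place: 4-chloro-3-methylphenyl in place of 2-fluoropyridin-4-yl on an aromatic carbon. Among the compounds with values here, nothing measured so far isolates what this exchange does in this assay, since compound 1 carries both a different aryl group and a different group on the shared core.

Given that compound 1 and compound 2 sit within scatter of each other despite different aryl groups, no step beyond the scatter is expected for compound 3, so a 1.1-fold lower number from compound 2 to compound 3 (0.02 log units; within the scatter) is estimated as small. Compound 3 is therefore expected to give about 420 nM in this assay, between 150 nM and 1200 nM.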

Compound 3, half-maximal effective concentration: 712 nM
Estimate against measurement, compound 3: 1.7-fold (0.23 log units) below; the range from low to high includes it.
By their numbers in this assay, from the lowest: compounds 2, 3 and 1 (each within the scatter of the next).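

In this assay, going by these compounds alone, the exchange of 2-fluoropyridin-4-yl for 4-chloro-3-methylphenyl gives a 1.6-fold higher number from compound 2 to compound 3 (0.21 log units; within the scatter), the first step that isolates a change in one place, and on these numbers the two compounds cannot be told apart. At this aromatic carbon, between two ring nitrogen atoms, a ring with a hetero atom and a hydrogen-bond acceptor and a ring of carbon only with no hydrogen-bond acceptor therefore leave the read-out within the same scatter, something the earlier comparison of compound 1 and compound 2 could not show, as those two differ in more than one place. No supporting measurement bears on this result, so it stands as an observation about these two groups alone.

As far as these compounds go, a single exchange does not define the range of groups this position accepts, and it remains open whether an aryl ring carrying a carboxylic acid or an amine, or a saturated ring such as cyclohexyl in the same place, would move the number beyond the scatter. Within the data shown here, the separate contribution of the group on the shared core where compound 1 differs from compound 2 also remains unresolved, as no step isolates it.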